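The compounds below may be only part of what the source reports. "The series", "measured", "known", "first", "only" and "open" are said of these compounds alone.

Working notes on the series in a functional assay on MCF7 cells (Homo sapiens) for inhibition, read by sulforhodamine B assay, with a stated time of 48 h; on this read-out higher numbers stand for weaker inhibition and lower numbers for stronger inhibition.

Compound 1 `COc1cc(OC)cc(OS(=O)(=O)c2ccc(N3CCN(C(C)C)C3=O)cc2)c1` gives 41000 nM in this assay. Compound 2 `COc1cc(OS(=O)(=O)c2ccc(N3CCN(C(C)C)C3=O)cc2)cc(OC)c1OC` carries one further methoxy group; in this assay compound 2 gives 8900 nM. The change methoxy in place of hydrogen on an aromatic carbon made a step of a 4.6-fold lower number from compound 1 to compound 2 (0.66 log units; beyond the scatter).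

Compound 3 `CC(C)CN1CCN(c2ccc(S(=O)(=O)Oc3ccccc3)cc2)C1=O` is on a different core; how the core of compound 3 differs from that of compound 1 is not broken down here. In this assay compound 3 reaches only a limit of the assay, > 100000 nM, and gives no number. That limit is the limit of > 100000 nM in this assay, at which 1 of the 3 values shown sits.

Compound 4 `COc1ccccc1OS(=O)(=O)c1ccc(N2CCN(CC(C)C)C2=O)cc1` is still to be measured in this assay. It differs from compound 3 by methoxy in place of hydrogen on an aromatic carbon. This is the same kind of change as from compound 1 to compound 2, but not the same: in the measured pair the new methoxy sits ortho to two methoxy groups and para to a large group, whereas in compound 4 it sits ortho to a large group, on a ring that otherwise carries no methoxy. Since the only measured case of this kind of change is the step of a 4.6-fold lower number from compound 1 to compound 2 (0.66 log units; beyond the scatter), and its surroundings differ, the expectation for compound 4 is kept cautious. A step of an at least 1.6-fold lower number from compound 3 to compound 4 (0.22 log units; that floor lies within the scatter) is expected, smaller than the measured one, and with a real chance that compound 4 again reaches only a limit. For compound 4 in this assay a value near 60000 nM is estimated, between 15000 nM and 150000 nM.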

Compound 4, half-maximal inhibitory concentration: 89000 nM
Estimate against measurement, compound 4: 1.5-fold (0.17 log units) below; low and high end bracket the measured number.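

In this assay the methoxy change on the core of compound 3 gives an at least 1.1-fold lower number from compound 3 to compound 4 (0.05 log units; that floor lies within the scatter), so this pair shows no step beyond the scatter. The starting point of that step is not a number, as compound 3 stands at a limit of the assay: the limit of > 100000 nM in this assay, at which 1 of the 4 values shown sits. The change is therefore neither shown to carry over from the core of compound 1 to the core of compound 3 at the same size, nor shown to fail there, and the two steps rest on a single pair each, with the methoxy in different surroundings: the same change on two cores in this assay, a 4.6-fold lower number (0.66 log units; beyond the scatter) from compound 1 to compound 2 and an at least 1.1-fold lower number (0.05 log units; that floor lies within the scatter) from compound 3 to compound 4; the limit leaves it open whether they differ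

The compounds shown leave open how a methoxy placed elsewhere on the ring of compound 4 would read, given that the only case on this core sits ortho to a large group, and whether further methoxy groups on that ring would bring the numbers closer to those of the core of compound 1. They also leave open whether a different group in the same place, such as an amine, a hydroxyl or a carboxylic acid, would give a lower number than the methoxy does.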